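Notes on the step from compound 2 to compound 3

The source may hold more compounds than are shown below. What is called first, only, known or untested is meant among the compounds shown, and "the series" means these compounds.

Compound 2 `O=C(NC1CCCCC1)C1CCN(Cc2ccccc2)CC1` carries a plain phenyl on the saturated chain carbon bound to the ring amine nitrogen. Among the compounds with values here, in an assay for displacement of a labelled ligand from Sigma non-opioid intracellular receptor 1 (Cavia porcellus) (on this read-out lower numbers stand for stronger inhibition and higher numbers for weaker inhibition), compound 2 gives 15 nM, the higher of the two numbers so far. Within the data shown here, compound 1 `O=C(NC1CCCCC1)C1CCN(Cc2ccc(Cl)cc2)CC1` gives 7.7 nM in this assay, and the single recorded step, a 1.9-fold higher number from compound 1 to compound 2 (0.29 log units; within the scatter), stays within the scatter. Compound 3 `O=C(NC1CCCCC1)C1CCN(Cc2ccc(Cl)cc2Cl)CC1` differs from compound 2 by 2,4-dichlorophenyl in place of phenyl on a saturated chain carbon bound to an amine nitrogen in a ring. Among the measured compounds shown here, only the chloro-to-hydrogen step bears on this change, and it was within the scatter; the second chlorine of compound 3 has no counterpart among the measured compounds. Because a 1.9-fold higher number from compound 1 to compound 2 (0.29 log units; within the scatter) was small, the expected step of a 2.5-fold lower number from compound 2 to compound 3 (0.40 log units; beyond the scatter) is also small, a slight lowering at most, not clearly beyond the scatter. Compound 3 is estimated at 6 nM in this assay, with a range from 2 nM to 18 nM.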

Compound 3, inhibition constant: 52 nM
Compound 3: the middle estimate sits 8.7-fold (0.94 log units) below what was measured, outside the stated range (above it).
By their numbers in this assay, from the lowest: compounds 1 and 2 (each within the scatter of the next); then compound 3.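

In this assay, the change to 2,4-dichlorophenyl on the saturated chain carbon bound to an amine nitrogen in a ring gives a 3.5-fold higher number from compound 2 to compound 3 (0.54 log units; beyond the scatter), so this position is not indifferent to chlorine substitution on the aromatic ring, as the step between compound 1 and compound 2 alone might have suggested. Within the data shown here, the further chloro gives a 6.8-fold higher number from compound 1 to compound 3 (0.83 log units; beyond the scatter), the first single-place step beyond the scatter, and it runs opposite to any gain expected from adding chlorine. Nothing measured on these compounds accounts for this shift.

The compounds shown leave open whether the higher number follows from chlorine itself or from where the second chlorine sits on the ring. A fluoro or a methoxy group in place of that chlorine would help separate these two readings.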